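The compounds below may be only part of what the source reports. "The series", "measured", "known", "first", "only" and "open" are said of these compounds alone.

Measured in an ADME assay on S9 fraction from liver (Homo sapiens) for metabolic stability, read by LC-MS, using NADPH, with stated times of 5 min and 60 min, tested at 5 uM; on this read-out lower numbers stand for a less stable compound and higher numbers for a more stable compound:
Compound 1 `COc1cc(C2CN(C(=O)c3cc(OCCO)ccn3)C2)ccc1OCc1ccc(C2CC2)cc1`: 47%
Compound 2 `COc1cc(C2CN(C(=O)c3cc(OC[C@@H](O)CO)ccn3)C2)ccc1OCc1ccc(C2CC2)cc1`: 63%
Compound 3 `COc1cc(C2CN(C(=O)c3cc(COCC(CO)(CO)CO)ccn3)C2)ccc1OCc1ccc(C2CC2)cc1`: 85%

Of the three, compound 3 stands highest at 85%, clear of both others. Compound 4 `COc1cc(C2CN(C(=O)c3cc(COCC(CO)CO)ccn3)C2)ccc1OCc1ccc(C2CC2)cc1` differs from compound 3 by one change hydrogen in place of hydroxymethyl on a saturated chain carbon bound to three saturated chain carbons.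

The closest measured precedent is a number 16 percentage points higher from compound 1 to compound 2 (beyond the scatter), where hydroxymethyl replaces hydrogen on a saturated chain carbon, the reverse kind of exchange on a different chain. The steps of a number 22 percentage points higher from compound 2 to compound 3 (beyond the scatter) and a number 38 percentage points higher from compound 1 to compound 3 (beyond the scatter) also bear on it, but each replaces a whole chain, so neither isolates one hydroxymethyl. Across these three compounds the number rises as hydroxymethyl groups are added, and none goes against that, though the set is small.

A modest fall is therefore expected in this assay, and the estimated change is a number 14 percentage points lower from compound 3 to compound 4 (beyond the scatter). Compound 4 is estimated at 71%, with an expected range from 57% to 85%.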

Compound 4, percent of the compound remaining in the Homo sapiens assay: 55%
Beside the measured number, compound 4's estimate is 16 percentage points above it; measured number outside the range, below it.
By their numbers in the Homo sapiens assay, from the lowest: compounds 1, 4 and 2 (each within the scatter of the next, the first and the last beyond it); then compound 3.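

In the Homo sapiens assay, the loss of one hydroxymethyl on a saturated chain carbon bound to three saturated chain carbons gives a number 30 percentage points lower from compound 3 to compound 4 (beyond the scatter), and this is the first step that isolates this group on this chain, with a comparable size for the reverse kind of exchange on another chain: the same change on two cores in the Homo sapiens assay, a number 16 percentage points higher (beyond the scatter) from compound 1 to compound 2 and a number 30 percentage points higher (beyond the scatter) from compound 4 to compound 3, 14 percentage points apart, within the scatter of two such steps

In the Homo sapiens assay, the remaining steps read a number 8 percentage points lower from compound 2 to compound 4 (within the scatter) and a number 8 percentage points higher from compound 1 to compound 4 (within the scatter), so the standing of compound 3 does not carry over to compound 4, although compound 4 keeps the same chain apart from that hydroxymethyl.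

In a physicochemical assay for solubility, in phosphate buffer, at pH 7.2 (a lower number here means a less soluble compound, a higher number a more soluble compound), compound 3 gives 1500 nM and compound 4 gives 4700 nM, so the same change runs against the stability read-out: the measured solubility of compound 3, 1500 nM, and of compound 4, 4700 nM, a 3.1-fold higher number (0.50 log units; beyond the scatter)

The compounds shown leave open whether an amine, a carboxylic acid or a methoxymethyl on that saturated chain carbon would keep the stability of compound 3 while matching the solubility of compound 4. They also leave open whether this step holds on a different core.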